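Swapping the pyridine methyl for azetidine on the core

A few compounds are considered here, and "the series" means these few. Any claim that something is new, unique, unknown or untested is made for them only; others in the source may bear on it.

Compound 1 `NS(=O)(=O)c1ccc(-c2nc(C(c3ccc(F)cc3)c3ccc(F)cc3)sc2CC(=O)O)cc1` is the anchor of this small set. In an in vitro functional assay on HEK285-7 cells for antagonist activity at prostaglandin D2 receptor 2 (Homo sapiens), read by BRET and beta-arrestin recruitment (a lower number here means a smaller maximal response, a higher number a larger maximal response), compound 1 gives 80%. Compound 2 `Cc1cc(-c2nc(C(c3ccc(F)cc3)c3ccc(F)cc3)sc2CC(=O)O)ccn1` carries a 2-methylpyridin-4-yl in place of the 4-sulfamoylphenyl of compound 1 on an aromatic carbon of the shared core, and in this assay compound 2 gives 80%. The step of no change at the digits printed from compound 1 to compound 2 (within the scatter) is the only measured one, and it shows that exchanging the whole aromatic substituent left the maximal response where it was. Compound 2 therefore stands level with compound 1, with no difference between them beyond the scatter.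

Compound 3 `O=C(O)Cc1sc(C(c2ccc(F)cc2)c2ccc(F)cc2)nc1-c1ccnc(N2CCC2)c1` is not yet measured. The change from compound 2 to compound 3 is azetidin-1-yl in place of methyl on an aromatic carbon. Going by the values given here, the one measured step, from compound 1 to compound 2, bears on it only loosely, since it replaced a far larger part of the molecule and produced no change; a smaller substitution on the same pyridine is, on that basis, expected to move the efficacy little or not at all, no change at the digits printed from compound 2 to compound 3 (within the scatter). The account expects compound 3 to give 80% in this assay, within 66% to 92%.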

Compound 3, largest response reached (reported as efficacy), in percent of the reference or control that the assay uses: 80%
The estimate for compound 3 equals the measured number at the digits printed; the measured number falls inside the stated range.
By their numbers in this assay, from the lowest: compounds 1, 2 and 3 (each within the scatter of the next).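

In this assay, azetidin-1-yl in place of methyl, on an aromatic carbon next to the ring nitrogen, gives no change at the digits printed from compound 2 to compound 3 (within the scatter). Unlike the earlier step, which exchanged the whole aromatic substituent, this one alters a single group on the pyridine, so it shows that this position can carry a four-membered non-aromatic ring of four heavy atoms instead of one carbon without moving the maximal response beyond the scatter. Set against the anchor, 2-(azetidin-1-yl)pyridin-4-yl in place of 4-sulfamoylphenyl gives no change at the digits printed from compound 1 to compound 3 (within the scatter), so three different aromatic substituents on the shared core now stand level in this read-out. No measurement at hand explains this flat result.

The compounds shown leave open whether a dimethylamino group, a methoxy group or a piperidine ring at this same position would also leave the maximal response level. They also leave open whether this insensitivity would persist if another part of the shared core were changed, for example if an amide replaced the carboxylic acid.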